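The source may report more compounds than this note shows. Statements on the series, on what has been measured and on what is new or still open speak of the compounds shown alone.

Measured so far in an assay on IMR-32 cells for displacement of a labelled ligand from corticotropin-releasing factor receptor 1 (Homo sapiens), read by scintillation counting, with a stated time of 2 h; a lower number here means a stronger inhibitor, a higher number a weaker inhibitor:
compound 1 `CCc1nc(NC(CC)CC)c(Cl)nc1-c1ccc(Cl)cc1Cl` gives 71 nM
compound 2 `CCc1nc(-c2ccc(OC)cc2O)c(CC)nc1NC(CC)CC` gives 1180 nM
compound 3 `CCc1nc(-c2ccc(OC(F)(F)F)cc2OC)c(OC)nc1NC(CC)CC` gives 6.1 nM

Compound 1 stands second highest of the three numbers. Compound 3 lies lower, beyond the scatter, and compound 2 lies higher, also beyond the scatter.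

Compound 4 `CCc1nc(NC(CC)CC)c(OC)nc1-c1ccc(Cl)cc1Cl` differs from compound 1 in one place: methoxy in place of chloro on an aromatic carbon. Within the data shown here, no pair of measured compounds isolates this change; compound 2 and compound 3 each differ from compound 1 at several positions, so their values can only hint. Still, compound 3, which carries methoxy at the same ring carbon, gives the lowest number in the set, while compound 2, with ethyl there, gives the highest. Taking this at face value, the move from chloro to methoxy on the core of compound 1 is expected to bring the number down by a moderate amount, beyond the scatter; the expected step is a 3.6-fold lower number from compound 1 to compound 4 (0.55 log units; beyond the scatter). Compound 4 is estimated at 20 nM, with a range from 5 nM to 80 nM.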

Compound 4, inhibition constant: 5.9 nM
The estimate for compound 4 lay 3.4-fold (0.53 log units) above the measured number, within the range that was stated.
By their numbers in this assay, from the lowest: compounds 4 and 3 (each within the scatter of the next); then compound 1; then compound 2.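

Methoxy in place of chloro on the aromatic carbon next to the ring nitrogen, ortho to a (pentan-3-yl)amino group and para to an ethyl group, gives a 12-fold lower number from compound 1 to compound 4 (1.08 log units; beyond the scatter) in this assay. Among these compounds, this is the first reading of the change with the rest of the molecule held fixed, and it shows that this one position alone can carry a large step, which the earlier compounds, differing at several positions, could not isolate. No measurement on hand gives a reason for the step.

Going by these compounds, the change has been read only on the background of compound 1, so whether a step of this size carries over to other substituents elsewhere on the core stays open. Also open, on these data alone, is how ethoxy, a longer alkoxy chain or a dimethylamino group at the same carbon would compare with methoxy.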